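From dimethylcarbamoyl to sulfo on one oxygen

A few compounds are considered here, and "the series" means these few. Any claim that something is new, unique, unknown or untested is made for them only; others in the source may bear on it.

Among the measured compounds shown here, in a physicochemical assay for solubility, in simulated intestinal fluid, with a stated time of 4 h (on this read-out higher numbers stand for higher solubility and lower numbers for lower solubility), compound 2 `CN(C)C(=O)OCCOc1cc2ncnc(Nc3ccc4scnc4c3)c2cc1S(=O)(=O)C(C)(C)C` gives 12 ug/mL, the higher of the two numbers so far, and compound 1 `CC(C)(C)S(=O)(=O)c1cc2c(Nc3ccc4scnc4c3)ncnc2cc1OCCO` gives 4 ug/mL. Compound 3 `CC(C)(C)S(=O)(=O)c1cc2c(Nc3ccc4scnc4c3)ncnc2cc1OCCOS(=O)(=O)O` keeps the shared core and changes one group, with sulfo in place of dimethylcarbamoyl on an oxygen on a saturated carbon. For the measured compounds named here, only one measured step bears on this oxygen, a 3.0-fold higher number from compound 1 to compound 2 (0.48 log units; beyond the scatter), and it is modest. Going by the values given here, no sulfo group has yet been measured here, so that step guides the direction only loosely. A rise in this assay is expected, probably larger than that modest step, though its size is highly uncertain. The estimate amounts to an 8.3-fold higher number from compound 2 to compound 3 (0.92 log units; beyond the scatter). For compound 3 the expected value is 100 ug/mL, with an estimated range from 15 ug/mL to 1000 ug/mL.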

Compound 3, solubility: 2460 ug/mL
Compound 3: the middle estimate sits 25-fold (1.39 log units) below what was measured; the whole stated range lies below it.
By their numbers in this assay, from the lowest: compound 1; then compound 2; then compound 3.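

In this assay, this oxygen on a saturated carbon turns out to be far more sensitive than the first pair could show: sulfo in place of dimethylcarbamoyl gives a 210-fold higher number from compound 2 to compound 3 (2.31 log units; beyond the scatter), and sulfo in place of hydrogen gives a 620-fold higher number from compound 1 to compound 3 (2.79 log units; beyond the scatter). Among the compounds shown here, both steps are large, whereas the only earlier step at this oxygen, a 3.0-fold higher number from compound 1 to compound 2 (0.48 log units; beyond the scatter), is modest, so the group placed here can move this read-out much further than that step suggested. No separate measurement is available to explain the size of these steps.

The compounds shown leave open whether sulfo is unusual here, or whether another group on this oxygen, such as a phosphate, a carboxylic acid or an amine, would give a similar number. They also leave open how a longer chain carrying the same sulfooxy group would behave in this assay.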